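This account rests on a few compounds, and the source may have more. Where it says the series, first, only, none or still open, it means among the compounds named here.

Compound 1 `Cn1c(-c2ccc(-c3cncnc3)cc2)nnc1C1(c2ccc(Cl)cc2)CCC1` gives > 4000 nM in an assay on isolated protein for inhibition of 11-beta-hydroxysteroid dehydrogenase type 2 (Mus musculus); on this read-out higher numbers stand for weaker inhibition and lower numbers for stronger inhibition.
Compound 2 `Cn1c(-c2ccc(-c3cnccn3)cc2F)nnc1C1(c2ccc(Cl)cc2)CCC1` gives > 4000 nM in this assay.

Compound 1 stands at a limit of the assay, not at a number. Compound 2 likewise stands at a limit, so nothing separates the two on the numbers shown. Both sit at the limit of > 4000 nM in this assay, at which 2 of the 2 values shown sit. Compound 3 `Cn1c(-c2ccc(C(=O)NC(C)(C)C)cc2)nnc1C1(c2ccc(Cl)cc2)CCC1` is the unmeasured partner: (tert-butyl)carbamoyl in place of pyrimidin-5-yl on an aromatic carbon. Within the data shown here, no measured step tells how such a change plays out here, so the expected step from compound 1 to compound 3 is a step that the limit leaves unreadable from compound 1 to compound 3, not beyond the scatter, and likely ending at a limit again. Compound 3 is therefore expected to give 8000 nM, within 3000 nM to 30000 nM.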

Compound 3, half-maximal inhibitory concentration: > 4000 nM
Compound 3 was reported as a limit; the forecaster's own chance of this, stated with the estimate: 70%; the middle value lies beyond the limit too.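

Compound 1 and compound 3 both stand at a limit in this assay, so no step between them can be read: the limit of > 4000 nM in this assay, at which 3 of the 3 values shown sit.

The compounds shown leave open how strongly any of them actually inhibits, and which change to the shared core would give a measurable number.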